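The source may report more compounds than this note shows. Statements on the series, on what has been measured and on what is new or still open speak of the compounds shown alone.

Measured compounds:
- compound 1 `CCCCCCCC/C=C\CCCCCCCC(=O)OCC1CCCCO1`: 29000 nM
- compound 2 `O=C(OCC1CCCCO1)c1ccc(-c2ccccc2)cc1`: 32000 nM
- compound 3 `O=C(OCC1CCCCO1)c1ccccc1`: 53000 nM

All three compounds were tested in an assay on membranes from cerebellum for inhibition of Fatty-acid amide hydrolase 1 (Rattus norvegicus); on this read-out lower numbers stand for stronger inhibition and higher numbers for weaker inhibition. Compound 1 gives 29000 nM, compound 2 gives 32000 nM and compound 3 gives 53000 nM. Compound 2 thus stands second highest of the three numbers, but its gaps to both neighbours lie within the scatter, so the three compounds cannot be ranked against each other on these data. Going by the values given here, the only step between compounds that differ in one place, a 1.7-fold higher number from compound 2 to compound 3 (0.22 log units; within the scatter), concerns the phenyl on the aromatic carbon and says nothing about the ester side of the molecule.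

Compound 4 `O=C(OCC1CO1)c1ccc(-c2ccccc2)cc1` is not yet measured. It differs from compound 2 in exactly one place: oxiran-2-yl in place of oxan-2-yl on a saturated chain carbon bound to an oxygen next to a carbonyl group. Among the compounds with values here, no measured pair shows this kind of change, so there is no step to lean on, and the expectation rests only on the fact that the three measured compounds, which differ considerably in the part attached to the carbonyl, all give similar numbers. The expected step in this assay is therefore no change at the digits printed from compound 2 to compound 4 (within the scatter), which is no change beyond the scatter. Compound 4 is estimated at 32000 nM, with a range from 8000 nM to 120000 nM.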

Compound 4, half-maximal inhibitory concentration: 35000 nM
For compound 4 the middle estimate is 1.1-fold (0.04 log units) below the measured one; the measured number falls inside the stated range.
By their numbers in this assay, from the lowest: compounds 1, 2, 4 and 3 (each within the scatter of the next).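

In this assay, going by these compounds alone, the group on the saturated chain carbon bound to an oxygen next to a carbonyl group goes from oxan-2-yl to oxiran-2-yl, and the outcome is a 1.1-fold higher number from compound 2 to compound 4 (0.04 log units; within the scatter), the first reading at this position, since the earlier step concerned only the phenyl on the aromatic carbon. A six-membered non-aromatic ring with 6 heavy atoms can thus give way to a three-membered one with 3 heavy atoms, each with its single ring oxygen, without the two compounds separating beyond the scatter, though this is one pair on one core and sets no rule for the position. Nothing available explains this result or says what role, if any, either ring plays.

The compounds shown leave open whether any group at this place would separate from oxan-2-yl, for example an amine, a carboxylic acid or a longer open chain without a ring. They also leave open whether oxiran-2-yl would read the same on the core of compound 1 or compound 3, where the part bound to the carbonyl is different.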